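Swapping one aromatic ring in a weak part of the series

The compounds below may be only part of what the source reports. "The series", "measured", "known", "first", "only" and "open" are said of these compounds alone.

In a functional assay on LN-229 cells (Homo sapiens) for antiproliferative activity, with a stated time of 72 h (on this read-out higher numbers stand for weaker inhibition and lower numbers for stronger inhibition), compound 3 (`Nc1ncnn2c([C@@H]3O[C@H](CO)[C@@H](O)[C@H]3O)cc(-c3ccsc3)c12`) gives 57700 nM. For the measured compounds named here, compound 1 (`Nc1ncnn2c([C@@H]3O[C@H](CO)[C@@H](O)[C@H]3O)cc(-c3ccc(F)cc3)c12`) gives 65600 nM, within the scatter of that number, while compound 2 (`Nc1ncnn2c([C@@H]3O[C@H](CO)[C@@H](O)[C@H]3O)cc(/C=C/c3ccccc3)c12`) gives 3900 nM, the only clearly lower number. Compound 4 (`Nc1ncnn2c([C@@H]3O[C@H](CO)[C@@H](O)[C@H]3O)cc(-c3ccccc3Cl)c12`) has 2-chlorophenyl in place of thiophen-3-yl on an aromatic carbon. Going by the values given here, the closest precedent is the exchange of one aromatic ring for another, a 1.1-fold lower number from compound 1 to compound 3 (0.06 log units; within the scatter), which stayed within the scatter. The large steps, a 17-fold lower number from compound 1 to compound 2 (1.23 log units; beyond the scatter) and a 15-fold higher number from compound 2 to compound 3 (1.17 log units; beyond the scatter), both involve the 2-phenylethenyl group of compound 2, which compound 4 lacks. Among the compounds with values here, no measured compound carries chlorine. No step beyond the scatter is therefore expected in this assay. The expected step is a 1.2-fold lower number from compound 3 to compound 4 (0.06 log units; within the scatter). Compound 4 is estimated at 50000 nM, with an expected range of 20000 nM to 100000 nM.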

Compound 4, half-maximal inhibitory concentration: > 100000 nM
Compound 4 gave a limit, no number (the forecaster's own chance of this, stated with the estimate: 15%); middle value at least 2.0-fold (0.30 log units) from the limit.
By their numbers in this assay, from the lowest: compound 2; then compounds 3 and 1 (each within the scatter of the next). At a limit, above all of these: compound 4.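

Compound 4 gave a limit, not a number: the limit of > 100000 nM in this assay, at which 1 of the 4 values shown sits. Its floors, an at least 1.7-fold higher number from compound 3 to compound 4 (0.23 log units; that floor lies within the scatter) and an at least 1.5-fold higher number from compound 1 to compound 4 (0.18 log units; that floor lies within the scatter), stay within the scatter, so 2-chlorophenyl at this aromatic carbon is not shown to differ from thiophen-3-yl or 4-fluorophenyl. The 2-phenylethenyl group of compound 2 remains clearly apart, with an at least 25-fold higher number from compound 2 to compound 4 (1.40 log units; beyond the scatter), and the three directly attached aromatic rings now all sit on the weak side of the series.

As far as these compounds go, how far compound 4 lies past its limit stays open. So does whether an amine or a longer chain on this carbon would match compound 2.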